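Fluoropyridine in place of cyclopropyl, near the limit

This account rests on a few compounds, and the source may have more. Where it says the series, first, only, none or still open, it means among the compounds named here.

Measured in a functional assay on KYSE-70 cells for antiproliferative activity against KYSE-70 cell line (Homo sapiens), read by MTT assay, with a stated time of 72 h (a lower number here means a stronger inhibitor, a higher number a weaker inhibitor), all three values being limits:
- compound 1 `O=C(Nc1cccc(F)c1)c1cc(=O)[nH]c2cc(-c3ccccc3F)ccc12`: > 20000 nM
- compound 2 `Cc1ccc(-c2ccc3c(C(=O)Nc4cccc(F)c4)cc(=O)[nH]c3c2)cc1`: > 20000 nM
- compound 3 `O=C(Nc1cccc(F)c1)c1cc(=O)[nH]c2cc(C3CC3)ccc12`: > 20000 nM

Compound 3 is known only as a limit, > 20000 nM. The whole set shows (the limit of > 20000 nM in this assay, at which 3 of the 3 values shown sit). Compound 4 `O=C(Nc1cccc(F)c1)c1cc(=O)[nH]c2cc(-c3cccnc3F)ccc12` carries 2-fluoropyridin-3-yl in place of cyclopropyl, on an aromatic carbon of the shared core: 2-fluoropyridin-3-yl in place of cyclopropyl on an aromatic carbon. Among the measured compounds shown here, the steps that bear on this change are a step that the two limits leave unreadable from compound 1 to compound 3 and a step that the two limits leave unreadable from compound 2 to compound 3. For the measured compounds named here, neither gives a size, so no step of definite size or direction can be expected in this assay, and a reading at the same limit is the likeliest outcome. The expected change is a number no higher from compound 3 to compound 4 (the limit leaves the size open). The estimate for compound 4 is 20000 nM, with an expected range of 7000 nM to 40000 nM.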

Compound 4, half-maximal inhibitory concentration: > 20000 nM
Compound 4: only a limit was reported (the forecaster's own chance of this, stated with the estimate: 80%); the middle value sits exactly at the limit.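

In this assay, among the compounds shown here, compound 4 gives > 20000 nM, which is a limit, so no step between compound 4 and compound 1, compound 2 or compound 3 can be read. The compounds shown leave open whether any change on the shared core gives a measurable value in this assay: the limit of > 20000 nM in this assay, at which 4 of the 4 values shown sit.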